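The compounds below may be only part of what the source reports. "The series", "measured", "known", "first", "only" and "open" are said of these compounds alone.

Three compounds share one core and differ at two places. Compound 1 `CN(C)CCCNc1nc(-c2ccc(NC(=O)Nc3ccc(F)cc3)cc2)nc2c(Cl)c(Cl)sc12` gives 980 nM in a functional assay on MDA-MB-231 cells (Homo sapiens) for cytotoxicity, read by MTT assay, with a stated time of 72 h; a lower number here means a stronger inhibitor, a higher number a weaker inhibitor. Compound 2 `CN(C)CCCNc1nc(-c2ccc(NC(=O)Nc3ccccc3Cl)cc2)nc2c(Cl)c(Cl)sc12` gives 1560 nM in this assay, and compound 3 `CN(C)CCNc1nc(-c2ccc(NC(=O)Nc3ccc(F)cc3)cc2)nc2c(Cl)c(Cl)sc12` gives 1240 nM in this assay. Compound 3 thus holds the second highest of the three numbers, although all three sit within the scatter of one another. The step of a 1.3-fold higher number from compound 1 to compound 3 (0.10 log units; within the scatter) alters the saturated chain, and the step of a 1.6-fold higher number from compound 1 to compound 2 (0.20 log units; within the scatter) alters the aryl group on the amide-type nitrogen; neither moves beyond the scatter. Compound 4 `CN(C)CCNc1nc(-c2ccc(NC(=O)Nc3ccccc3Cl)cc2)nc2c(Cl)c(Cl)sc12` has not yet been measured. It differs from compound 3 by 2-chlorophenyl in place of 4-fluorophenyl on an amide-type nitrogen, the same change already seen in the step of a 1.6-fold higher number from compound 1 to compound 2 (0.20 log units; within the scatter), which stayed within the scatter. Compound 4 is therefore expected to show a step of a 1.5-fold higher number from compound 3 to compound 4 (0.19 log units; within the scatter), small and not beyond the scatter. Compound 4 is estimated at 1900 nM in this assay, with a range from 950 nM to 3800 nM.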

Compound 4, half-maximal inhibitory concentration: 1350 nM
Compound 4: middle estimate off by 1.4-fold (0.15 log units), on the high side; the measured number falls inside the stated range.
By their numbers in this assay, from the lowest: compounds 1, 3, 4 and 2 (each within the scatter of the next).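

The change from 4-fluorophenyl to 2-chlorophenyl on the amide-type nitrogen can now be read on a second core, giving a 1.1-fold higher number from compound 3 to compound 4 (0.04 log units; within the scatter) in this assay, and its two readings agree: the same change on two cores in this assay, a 1.6-fold higher number (0.20 log units; within the scatter) from compound 1 to compound 2 and a 1.1-fold higher number (0.04 log units; within the scatter) from compound 3 to compound 4, 1.5-fold (0.16 log units) apart, within the scatter of two such steps. The chain change can likewise now be read with 2-chlorophenyl in place, giving a 1.2-fold lower number from compound 2 to compound 4 (0.06 log units; within the scatter), and these two readings also agree: the same change on two cores in this assay, a 1.3-fold higher number (0.10 log units; within the scatter) from compound 1 to compound 3 and a 1.2-fold lower number (0.06 log units; within the scatter) from compound 2 to compound 4, 1.5-fold (0.16 log units) apart, within the scatter of two such steps. Each change thus stays within the scatter on both cores, whichever group stands at the other place.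

Still open, as far as these compounds go, is whether any other group at these two places would move the number beyond the scatter. An unsubstituted phenyl or a pyridine ring on the amide-type nitrogen could test this, as could a longer chain or a morpholine in place of the dimethylamino group.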